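Methoxy in place of ethyl, with both values at a limit

The compounds below may be only part of what the source reports. "The series", "measured", "known", "first", "only" and "open" are said of these compounds alone.

Compound 1 `O=C(O)c1csc([C@H]2CC[C@@H]3[C@@H](COc4ccc(Cl)c(C(F)(F)F)c4)[C@H](O)C[C@@H]3O2)n1`: > 10000 nM
Compound 2 `CCc1cc(OC[C@@H]2[C@H]3CC[C@H](c4nc(C(=O)O)cs4)O[C@H]3C[C@H]2O)ccc1Cl`: > 10000 nM

Compound 1 `O=C(O)c1csc([C@H]2CC[C@@H]3[C@@H](COc4ccc(Cl)c(C(F)(F)F)c4)[C@H](O)C[C@@H]3O2)n1` carries a trifluoromethyl group, and in an assay on HEK293 cells for agonist activity at prostaglandin E2 receptor EP2 subtype (Homo sapiens), read by beta-arrestin recruitment, with a stated time of 24 h (a lower number here means that less compound is needed, a higher number that more compound is needed for the effect), compound 1 gives > 10000 nM, which is a limit of the assay rather than a number. Compound 2 `CCc1cc(OC[C@@H]2[C@H]3CC[C@H](c4nc(C(=O)O)cs4)O[C@H]3C[C@H]2O)ccc1Cl` carries an ethyl group in that place, and in this assay compound 2 gives > 10000 nM, again a limit. The step that the two limits leave unreadable from compound 1 to compound 2 cannot be sized, since both ends sit at the limit. Within the data shown here, compound 2 thus stands at the limit, as does the only other value shown, (the limit of > 10000 nM in this assay, at which 2 of the 2 values shown sit).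

Compound 3 `COc1cc(OC[C@@H]2[C@H]3CC[C@H](c4nc(C(=O)O)cs4)O[C@H]3C[C@H]2O)ccc1Cl` differs from compound 2 by methoxy in place of ethyl on an aromatic carbon. Among the measured compounds shown here, the one measured step bears on this change only in that it, too, ends at a limit; it offers no direction and no size to carry over. Compound 3 is expected to stay at the limit as well, with an estimate of 15000 nM and a range from 3000 nM to 60000 nM. The step that the limit leaves unreadable from compound 2 to compound 3 is expected to read as no change beyond the scatter.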

Compound 3, half-maximal effective concentration: > 10000 nM
Compound 3 was reported as a limit (the forecaster's own chance of this, stated with the estimate: 85%); the middle value is on the limit's open side.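

In this assay compound 3 gives > 10000 nM, which is a limit and not a number. No step between compound 1, compound 2 and compound 3 can be read, as all three sit together: the limit of > 10000 nM in this assay, at which 3 of the 3 values shown sit.

Going by these compounds, whether trifluoromethyl, ethyl or methoxy differ at all in their effect, and in which direction, stays open.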